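Side-chain swap from compound 2: working notes

The source may report more compounds than this note shows. Statements on the series, on what has been measured and on what is new or still open speak of the compounds shown alone.

Measured so far in a functional assay on MCF7 cells (Homo sapiens) for inhibition, read by MTT assay, with a stated time of 48 h, tested at 10 uM; on this read-out lower numbers stand for less inhibition of growth and higher numbers for more inhibition of growth at the one concentration tested:
- compound 1 (`Cc1cc(=O)c2c(O)cc(OCc3ccccc3Br)c([C@H]3CCN(C)C[C@H]3O)c2o1`) with 45% measured
- compound 2 (`CCN(CC)Cc1c(O)c([C@H]2CCN(C)C[C@H]2O)c2oc(C)cc(=O)c2c1O`) with 24% measured

Compound 2 stands lowest of the two numbers, and the gap up to compound 1 lies beyond the usual scatter. Still unmeasured is compound 3 (`Cc1cc(=O)c2c(O)c(CN3CC(O)CC3C(=O)O)c(O)c([C@H]3CCN(C)C[C@H]3O)c2o1`), which carries 2-carboxy-4-hydroxypyrrolidin-1-yl in place of diethylamino on a saturated chain carbon bound to an aromatic carbon. For the measured compounds named here, no measured pair differs in one place only, so the data offer no direct guide to this change. The expectation therefore starts from compound 2 at 24% as its anchor. In this assay the expected step of a number 4 percentage points lower from compound 2 to compound 3 (within the scatter) is small and slightly downward, with nothing expected beyond the scatter. For compound 3 the estimated value is 20%, with an expected range from 5% to 38% on this read-out.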

Compound 3, percent growth inhibition at one concentration: 25%
The estimate for compound 3 lay 5 percentage points below the measured number, within the range that was stated.
By their numbers in this assay, from the lowest: compounds 2 and 3 (each within the scatter of the next); then compound 1.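

In this assay, replacing diethylamino with 2-carboxy-4-hydroxypyrrolidin-1-yl on a saturated chain carbon bound to an aromatic carbon gives a number 1 percentage points higher from compound 2 to compound 3 (within the scatter). For the compounds shown here, this is the first single-place comparison, and at this place the read-out does not separate the open diethylamino group from a five-membered non-aromatic ring bearing carboxy and hydroxy groups. No measured evidence bearing on this result is available.

Open, from the compounds shown here alone, is whether unsubstituted pyrrolidin-1-yl, piperidin-1-yl or morpholin-4-yl on the same carbon would read differently from these two groups, and whether the carboxylic acid or the hydroxy group on the ring matters when present alone. Compound 1 differs from compound 2 and compound 3 in more than one place, so it gives no guide to this position.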